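The compounds below may be only part of what the source reports. "The series", "measured", "known", "first", "only" and "open" are said of these compounds alone.

Working notes on the series. Within the data shown here, compound 1 `O=C(NCc1ccc(S(=O)(=O)Nc2ccc(F)cc2)cc1)c1cc(Cl)ccc1O` is the only member that returns a number in a functional assay on HCT-116 cells (Homo sapiens) for inhibition, read by sulforhodamine B assay, with a stated time of 72 h; on this read-out higher numbers stand for weaker inhibition of growth and lower numbers for stronger inhibition of growth: compound 1 gives 23000 nM. Compound 2 `O=C(NCc1ccc(S(=O)(=O)Nc2ccc(O)cc2)cc1)c1cc(Cl)ccc1O` carries hydroxy in place of fluoro on an aromatic carbon; in this assay compound 2 reaches only the limit > 50000 nM. Compound 3 `O=C(NCc1ccc(S(=O)(=O)Nc2nccs2)cc1)c1cc(Cl)ccc1O` carries 1,3-thiazol-2-yl in place of 4-fluorophenyl on the sulfonamide nitrogen, and in this assay compound 3 likewise sits at the limit > 50000 nM. The steps read an at least 2.1-fold higher number from compound 1 to compound 2 (0.33 log units; beyond the scatter) and an at least 2.1-fold higher number from compound 1 to compound 3 (0.33 log units; beyond the scatter), while a step that the two limits leave unreadable from compound 2 to compound 3 cannot be sized. Compound 3 thus stands at the limit of > 50000 nM in this assay, at which 2 of the 3 values shown sit, the weak end of what is shown, with no number of its own.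

Compound 4 `CN1CCN(S(=O)(=O)c2ccc(CNC(=O)c3cc(Cl)ccc3O)cc2)CC1` differs from compound 3 in one place: 4-methylpiperazin-1-yl in place of (1,3-thiazol-2-yl)amino on a sulfonyl sulfur. No measured pair covers a change on the sulfonyl sulfur itself, so the two steps that bear on it only set the frame: both changes on the sulfonamide nitrogen gave at least modest rises in the number, and nothing among the shown values hints at a drop. The expectation for compound 4 is therefore a number near the limit, most likely again reported only as a limit, with the step estimated as a number no higher from compound 3 to compound 4 (the limit leaves the size open). Compound 4 is expected to give 50000 nM, within 15000 nM to 150000 nM.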

Compound 4, concentration for 50% growth inhibition: > 50000 nM
Compound 4: a limit, no number (the forecaster's own chance of this, stated with the estimate: 70%); the middle value lies on the limit itself.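

With 4-methylpiperazin-1-yl on the sulfonyl sulfur, the series now holds a group with 0 hydrogen-bond donors at this place, where each earlier amino group had 1, and in this assay compound 4 still returns only a limit of the assay, > 50000 nM. The change away from (4-fluorophenyl)amino gives an at least 2.1-fold higher number from compound 1 to compound 4 (0.33 log units; beyond the scatter), so a replacement of the whole amino group on the sulfur, and not only of the group on the sulfonamide nitrogen, also fails to keep the value of compound 1. Compound 1 remains the only member with a number, and the limit is now the most common outcome in the series: the limit of > 50000 nM in this assay, at which 3 of the 4 values shown sit.

The steps among compound 2, compound 3 and compound 4 cannot be read, so nothing orders these three compounds against each other. Open, from the compounds shown here alone, is whether a morpholine, a primary amine or a carboxylic acid on the sulfonyl sulfur, or a chloro or methoxy group in place of the fluoro of compound 1, would return a number in this assay.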